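Swapping the furan arm for a hydroxy-methoxybenzyl arm

The compounds below may be only part of what the source reports. "The series", "measured", "known", "first", "only" and "open" are said of these compounds alone.

Of the compounds shown here, three have been measured so far in an ADME assay for permeability, using PAMPA, with a stated time of 30 min, at pH 7.4; a lower number here means that the compound crosses the layer more slowly, a higher number that the compound crosses the layer faster. Compound 1 `COc1cccc(CNCCCNc2ccnc3cc(Oc4ccccc4)ccc23)c1O` gives 317 10^-6 cm/s. Compound 2 `CC(C)Cc1ccc2c(NCCCNCc3ccco3)ccnc2c1` gives 23 10^-6 cm/s. Compound 3 `CN(C)c1cccc(Oc2ccc3c(NCCCNCc4ccco4)ccnc3c2)c1` gives 317 10^-6 cm/s. Among these, compound 3 stands level with compound 1 at the digits reported, the two together forming the top of the three numbers, while compound 2 sits furthest away. Among the measured compounds shown here, the one single-point step measured so far, a 14-fold higher number from compound 2 to compound 3 (1.14 log units; beyond the scatter), is large and concerns the other end of the shared core.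

Compound 4 `COc1cccc(CNCCCNc2ccnc3cc(Oc4cccc(N(C)C)c4)ccc23)c1O` differs from compound 3 in one place: 2-hydroxy-3-methoxyphenyl in place of furan-2-yl on a saturated chain carbon bound to an amine nitrogen. For the measured compounds named here, no measured step covers exactly this change. What the numbers do show is that compound 1, which carries the same 2-hydroxy-3-methoxybenzyl group, reaches the same value in this assay as compound 3, which carries the furan arm. On that basis the expected step of a 1.1-fold lower number from compound 3 to compound 4 (0.02 log units; within the scatter) is small, not beyond the scatter. Compound 4 is therefore estimated to give 300 10^-6 cm/s, within a range from 150 10^-6 cm/s to 600 10^-6 cm/s.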

Compound 4, apparent permeability: 317 10^-6 cm/s
Beside the measured number, compound 4's estimate is 1.1-fold (0.02 log units) below it; measured number inside the range.
By their numbers in this assay, from the lowest: compound 2; then compounds 1, 3 and 4 (each within the scatter of the next).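

In this assay the arm on the saturated chain carbon bound to an amine nitrogen now has its own measured step: 2-hydroxy-3-methoxyphenyl in place of furan-2-yl gives no change at the digits printed from compound 3 to compound 4 (within the scatter) even though the entering group has more heavy atoms and brings a hydrogen-bond donor. With that arm in place, dimethylamino in place of hydrogen on an aromatic carbon gives no change at the digits printed from compound 1 to compound 4 (within the scatter) at the other end of the shared core. No measured evidence is available to explain why either change leaves the number as it stands.

The compounds shown leave open whether an arm ending in a carboxylic acid, or a longer chain linking the two amine nitrogens, would give the same number. They also leave open whether this arm change would read the same with the isobutyl group of compound 2, which gives 23 10^-6 cm/s with the furan arm.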